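From a Methyl to a Hydroxylated Chain on Compound 2

This account rests on a few compounds, and the source may have more. Where it says the series, first, only, none or still open, it means among the compounds named here.

Compound 2 `Cn1cc(-c2ccc(F)cc2)c(=O)c2c(Nc3ccc(Oc4ccnc(NC(=O)C5CC5)c4)c(F)c3)nccc21` stands lowest of the three compounds measured in a functional assay on MKN-45 cells (Homo sapiens) for antiproliferative activity, read by MTT assay, with a stated time of 72 h, tested at 10 uM (on this read-out higher numbers stand for more inhibition at the one concentration tested (going by the name of the read-out) and lower numbers for less inhibition), where compound 2 gives 30.9%. Among the measured compounds shown here, compound 1 `CCCC(=O)Nc1cc(Oc2ccc(Nc3nccc4[nH]cc(-c5ccc(F)cc5)c(=O)c34)cc2F)ccn1` gives 64.6% and compound 3 `CC(C)C(=O)Nc1cc(Oc2ccc(Nc3nccc4[nH]cc(-c5ccc(F)cc5)c(=O)c34)cc2F)ccn1` gives 95.4%; both differ from compound 2 in more than one place, so no single step joins them to it. For the measured compounds named here, the only step measured in one place, a number 30.8 percentage points higher from compound 1 to compound 3 (beyond the scatter), concerns the acyl group on the amide and does not touch the change now considered. Compound 4 `CC(C)(O)Cn1cc(-c2ccc(F)cc2)c(=O)c2c(Nc3ccc(Oc4ccnc(NC(=O)C5CC5)c4)c(F)c3)nccc21` differs from compound 2 by 1-hydroxy-1-methylethyl in place of hydrogen on a saturated chain carbon bound to an aromatic nitrogen. Going by the values given here, no measured step bears on this change, so its direction stays open. Compound 4 is expected to show a number 14.1 percentage points higher from compound 2 to compound 4 (beyond the scatter). Compound 4 is therefore estimated at 45%, within 15% to 75%.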

Compound 4, a percentage reported as inhibition, at one concentration (the size of the read-out at that concentration, not a potency): 44.3%
Beside the measured number, compound 4's estimate is 0.7 percentage points above it, and the stated range covers the measured number.
By their numbers in this assay, from the lowest: compound 2; then compound 4; then compound 1; then compound 3.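

Among the compounds shown here, this is the first step read at this position: in this assay there is a number 13.4 percentage points higher from compound 2 to compound 4 (beyond the scatter) with 1-hydroxy-1-methylethyl in place of hydrogen on a saturated chain carbon bound to an aromatic nitrogen. The position therefore takes this larger hydroxylated group with a modest gain rather than a loss on this read-out. Nothing available accounts for the gain. On these data alone, whether an amine or a carboxylic acid on the same chain would give a similar number stays open. So does whether the change would carry over to the isopropyl amide of compound 3.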